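Swapping the Fluorophenyl of Compound 1 for Hydroxyphenyl

The compounds below may be only part of what the source reports. "The series", "measured", "known", "first", "only" and "open" are said of these compounds alone.

Three compounds sharing one core were tested in a functional assay on MDA-MB-231 cells (Homo sapiens) for cytotoxicity, read by MTT assay, with a stated time of 48 h; a lower number here means a stronger inhibitor, a higher number a weaker inhibitor. Compound 1 `O=C(/C=C/c1ccc2c(c1)B(O)OC2)c1ccc(F)cc1` gives 1600 nM, the lowest of the three numbers; compound 2 `CSc1ccc(C(=O)/C=C/c2ccc3c(c2)B(O)OC3)cc1` gives 9800 nM and compound 3 `CCOC(=O)c1ccc(C(=O)/C=C/c2ccc3c(c2)B(O)OC3)cc1` gives 13000 nM. The not yet measured compound 4 `O=C(/C=C/c1ccc2c(c1)B(O)OC2)c1cccc(O)c1` differs from compound 1 by 3-hydroxyphenyl in place of 4-fluorophenyl on a carbonyl carbon. Two measured steps also alter the group on the carbonyl carbon of compound 1: a 6.1-fold higher number from compound 1 to compound 2 (0.79 log units; beyond the scatter) and an 8.1-fold higher number from compound 1 to compound 3 (0.91 log units; beyond the scatter), both modest rises in the number. The change to compound 4 is not the same as either, so the match is loose, but both steps point toward a somewhat higher number. Compound 4 is therefore expected to give 4000 nM, between 1500 nM and 12000 nM, an expected 2.5-fold higher number from compound 1 to compound 4 (0.40 log units; beyond the scatter).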

Compound 4, half-maximal inhibitory concentration: 2700 nM
Beside the measured number, compound 4's estimate is 1.5-fold (0.17 log units) above it, within the range that was stated.
By their numbers in this assay, from the lowest: compounds 1 and 4 (each within the scatter of the next); then compounds 2 and 3 (each within the scatter of the next).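

The earlier changes on this carbonyl carbon, to methylsulfanyl and ethoxycarbonyl, each moved the number beyond the scatter, whereas 3-hydroxyphenyl in place of 4-fluorophenyl gives a 1.7-fold higher number from compound 1 to compound 4 (0.23 log units; within the scatter) and stays within it. Within the data shown here, this is the first change here that leaves the number within the scatter of compound 1, even with a hydrogen-bond donor and acceptor entering. No measured evidence accounts for this result. Going by these compounds, the group and its place on the ring change together, so 4-hydroxyphenyl and 3-fluorophenyl remain open. Also open, on these data alone, is how an amine or a carboxylic acid on this ring would read.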